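A few compounds are considered here, and "the series" means these few. Any claim that something is new, unique, unknown or untested is made for them only; others in the source may bear on it.

For the measured compounds named here, in an assay on isolated protein for inhibition of glucose-6-phosphatase catalytic subunit 1 (Rattus norvegicus), tested at 100 uM (on this read-out higher numbers stand for more inhibition at the one concentration tested (going by the name of the read-out) and lower numbers for less inhibition), the three compounds measured so far sit close together. Compound 1 `N=C(N)/N=C(\S)Nc1ccccn1` gives 20%. Compound 2 `COC(=O)C(C)/N=C(\S)Nc1ccccn1` gives 17.7%. Compound 3 `CCOC(=O)CC/N=C(\S)Nc1ccccn1` gives 18%, which is the second highest of the three numbers; the nearest number to it is that of compound 2, which lies within the scatter, and the furthest is that of compound 1, which also lies within the scatter. No difference among the three can therefore be read as a real change in this assay, and the set gives no sign that the chain carrying the ester, whether present or not and whatever its length, moves the read-out.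

Compound 4 `CCOC(=O)CC/N=C(\S)Nc1ccc(Cl)cn1` has not yet been measured. It differs from compound 3 in one place: chloro in place of hydrogen on an aromatic carbon. Going by the values given here, since no step between two measured compounds is known here, and since the three numbers in this assay all fall within the scatter of one another, the account expects no step beyond the scatter in this assay, in either direction, for the change to compound 4. The expected step is no change at the digits printed from compound 3 to compound 4 (within the scatter). Compound 4 is estimated to give 18%, with a range from 8% to 30% in this assay.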

Compound 4, a percentage reported as inhibition, at one concentration (the size of the read-out at that concentration, not a potency): 54.4%
Compound 4: the middle estimate sits 36.4 percentage points below what was measured, outside the stated range (above it).
By their numbers in this assay, from the lowest: compounds 2, 3 and 1 (each within the scatter of the next); then compound 4.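

In this assay, for the compounds shown here, chloro in place of hydrogen on an aromatic carbon, two atoms from the ring nitrogen and para to a large group, gives a number 36.4 percentage points higher from compound 3 to compound 4 (beyond the scatter), the only step in the set that lies beyond the scatter. Going by these compounds alone, compounds 1, 2 and 3 all carry hydrogen at this place and differ in the chain, and their numbers lie within the scatter of one another, so this ring carbon is the first place where a change moves the read-out, and the entering group is a single heavy atom with no ring, no hydrogen-bond donor or acceptor and no net charge. Nothing available here bears on why the step is this large.

The compounds shown leave open whether the step belongs to chloro itself or would also appear with fluoro, bromo, methyl or methoxy at that same place, or with chloro on another carbon of the ring. They also leave open whether chloro gives a step of similar size when the ethyl ester chain is replaced by the chain of compound 1 or of compound 2, or by a carboxylic acid.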